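Aryl amine swap on a shared enone series

The compounds below may be only part of what the source reports. "The series", "measured", "known", "first", "only" and "open" are said of these compounds alone.

The series is followed in a functional assay on Bel-7402 cells (Homo sapiens) for cytotoxicity, read by MTT assay; a lower number here means a stronger inhibitor, a higher number a weaker inhibitor. Compound 3 `COc1cccc(/C=C/C(=O)c2sc(Nc3cccc(Cl)c3)nc2C)c1` gives > 25000 nM there, a limit of the assay rather than a number. Compound 1 `COc1cccc(/C=C/C(=O)c2sc(Nc3ccc(Cl)cc3)nc2C)c1` also gives > 25000 nM, again a limit. The step that the two limits leave unreadable from compound 1 to compound 3 therefore cannot be read in size or direction. Compound 2 `Cc1ccc(Nc2nc(C)c(C(=O)/C=C/c3ccc(Cl)cc3)s2)cc1` sits at > 25000 nM, once more a limit. All that the measurements offer is the limit of > 25000 nM in this assay, at which 3 of the 3 values shown sit.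

Compound 4 `COc1cccc(/C=C/C(=O)c2sc(Nc3ccc(C)cc3)nc2C)c1` differs from compound 3 by 4-methylphenyl in place of 3-chlorophenyl on a nitrogen on an aromatic ring. No readable measured step bears on this change. For compound 4 the step that the limit leaves unreadable from compound 3 to compound 4 is expected to stay within scatter, with a strong chance that only a limit is reported again. The estimate for compound 4 is 30000 nM, with a range from 8000 nM to 100000 nM.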

Compound 4, half-maximal inhibitory concentration: > 25000 nM
Compound 4 was reported as a limit; the forecaster's own chance of this, stated with the estimate: 80%; the middle value does not contradict the limit.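

Among the compounds shown here, compound 4 is again only a limit, and no step from compound 1, compound 2 or compound 3 to compound 4 can be read: the limit of > 25000 nM in this assay, at which 4 of the 4 values shown sit. Left open is whether any aryl change on the shared core gives a readable value in this assay at all.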